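Changing the sulfonyl aryl group in a factor X series

The source may report more compounds than this note shows. Statements on the series, on what has been measured and on what is new or still open speak of the compounds shown alone.

Compound 3 `CC(C)(C)c1ccc(S(=O)(=O)N[C@H]2CCN(Cc3cc4c[nH]ccc-4n3)C2=O)cc1` is the starting point. In an assay on isolated protein for inhibition of coagulation factor X (Oryctolagus cuniculus), tested at 1 uM (on this read-out lower numbers stand for less inhibition and higher numbers for more inhibition at the one concentration tested (going by the name of the read-out)), compound 3 gives 14%. Compound 2 `CC(C)(C)c1ccc(S(=O)(=O)N[C@H]2CCN(CCNc3ccncc3)C2=O)cc1` gives in this assay 14%, and compound 1 `CC(C)(C)c1ccc(S(=O)(=O)N[C@H]2CCN(Cc3cc4[nH]cccc-4n3)C2=O)cc1` gives in this assay 22%. On these numbers compound 3 stands level with compound 2, the two together at the low end of the three; the step of a number 8 percentage points lower from compound 1 to compound 3 (within the scatter) lies within the scatter, as do a number 8 percentage points lower from compound 1 to compound 2 (within the scatter) and no change at the digits printed from compound 2 to compound 3 (within the scatter).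

Compound 4 `O=C1[C@@H](NS(=O)(=O)c2cc3ncccc3s2)CCN1Cc1cc2c[nH]ccc-2n1` differs from compound 3 at the other end of the molecule: a group of 9 heavy atoms (7 carbon, 1 nitrogen, 1 sulfur; one five-membered aromatic ring with 1 hetero atom, one six-membered aromatic ring with 1 hetero atom) in place of a group of 10 heavy atoms (10 carbon; one six-membered aromatic ring of carbon only), on a sulfonyl sulfur. Among the measured compounds shown here, none of the measured steps touches the sulfonyl sulfur; all three exchange the group on the saturated chain carbon bound to the amide-type nitrogen in the ring, and all three stay within the scatter. For the measured compounds named here, there is thus no measured step that bears on this change, and no direction can be read from the series. The expectation for compound 4 rests on the value of compound 3 alone, which gives 14%. The step of a number 2 percentage points higher from compound 3 to compound 4 (within the scatter) is therefore expected to remain within the scatter. Compound 4 is estimated to give 16% in this assay, with a range from 0% to 45%.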

Compound 4, a percentage reported as inhibition, at one concentration (the size of the read-out at that concentration, not a potency): 61%
Compound 4: middle estimate off by 45 percentage points, on the low side; measured number above the stated range.
By their numbers in this assay, from the lowest: compounds 2, 3 and 1 (each within the scatter of the next); then compound 4.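

The sulfonyl sulfur proves to be a place where this assay responds strongly: with the group on the other end of the molecule held constant, replacing 4-(tert-butyl)phenyl with the group carrying one five-membered and one six-membered aromatic ring, each with 1 hetero atom, gives a number 47 percentage points higher from compound 3 to compound 4 (beyond the scatter). Among the compounds shown here, the earlier compounds all carry 4-(tert-butyl)phenyl and vary only the group on the saturated chain carbon bound to the amide-type nitrogen in the ring, so their steps, all within the scatter, said nothing about this position, and this is the only step that lies beyond the scatter. No measurement at hand accounts for the size of this step.

The exchange alters several things at once, including the ring count, the nitrogen and sulfur atoms and the hydrogen-bond acceptor count, so the compounds shown do not separate which of these goes with the higher number, and a plain phenyl or a thiophene ring on the sulfonyl sulfur would help to divide them. As far as these compounds go, it also remains open whether the entering group would give a step of similar size with the groups of compound 1 or compound 2 at the other end of the molecule.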